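The compounds below may be only part of what the source reports. "The series", "measured", "known", "first", "only" and "open" are said of these compounds alone.

Working notes on the series.

Compound 1 `N=C(N)NCCC[C@@H](NC(=O)[C@@H]1Cc2ccccc2CN1)C(=O)N[C@H](CCCNC(=N)N)C(=O)N[C@@H](CCC(N)=O)C(=O)N[C@@H](CC1CCCCC1)C(=O)N[C@H]1CSSC[C@@H](C(N)=O)NC1=O` is measured in an ADME assay on a cell-free system (plasma, Rattus norvegicus, strain Wistar) for metabolic stability, read by HPLC (on this read-out lower numbers stand for a shorter-lived compound and higher numbers for a longer-lived compound), at 0.75 h. Going by the values given here, compound 2 `N=C(N)NCCC[C@@H](NC(=O)[C@H]1NCCc2ccccc21)C(=O)N[C@H](CCCNC(=N)N)C(=O)N[C@@H](CCC(N)=O)C(=O)N[C@@H](CC1CCCCC1)C(=O)N[C@H]1CSSC[C@@H](C(N)=O)NC1=O`, the one measured neighbour, gives in this assay a value of 0.75 h. The step of no change at the digits printed from compound 1 to compound 2 (within the scatter) carries the shift from 1,2,3,4-tetrahydroisoquinolin-3-yl to 1,2,3,4-tetrahydroisoquinolin-1-yl on a carbonyl carbon. Compound 1 therefore stands level with compound 2; neither can be called the longer-lived of the two.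

Compound 3 `N=C(N)NCCC[C@@H](NC(=O)[C@@H]1Cc2ccccc2CN1)C(=O)N[C@H](CCCNC(=N)N)C(=O)N[C@@H](CCC(N)=O)C(=O)N[C@@H](CC1CCCCC1)C(=O)N[C@H]1C[Se][Se]C[C@@H](C(N)=O)NC1=O` is not yet measured. It differs from compound 1 by a group of 12 heavy atoms (6 carbon, 2 nitrogen, 2 oxygen, 2 selenium; one eight-membered non-aromatic ring with 3 hetero atoms) in place of a group of 12 heavy atoms (6 carbon, 2 nitrogen, 2 oxygen, 2 sulfur; one eight-membered non-aromatic ring with 3 hetero atoms), on an amide-type nitrogen, on an amide-type nitrogen whose other neighbour is a carbonyl carbon. Among the compounds with values here, no measured step touches this part of the molecule: the only step available, from compound 1 to compound 2, concerns the tetrahydroisoquinolinyl group and so does not bear on the exchange of the sulfur-containing ring for the selenium-containing one. The expectation for compound 3 therefore rests on compound 1 alone, and the expected step of a 1.2-fold higher number from compound 1 to compound 3 (0.08 log units; within the scatter) is set as no change beyond the scatter, with a range widened to allow for the untested exchange. On that basis compound 3 is estimated in this assay at 0.9 h, between 0.35 h and 2.5 h.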

Compound 3, half-life: 6 h
Compound 3: middle estimate off by 6.7-fold (0.82 log units), on the low side, outside the stated range (above it).
By their numbers in this assay, from the lowest: compounds 1 and 2 (each within the scatter of the next); then compound 3.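

In this assay the ring on the amide-type nitrogen whose other neighbour is a carbonyl carbon proves to be a place where the read-out moves: putting two selenium atoms where two sulfur atoms stood, with the remaining counted heavy atoms and the eight-membered ring unchanged, gives an 8.0-fold higher number from compound 1 to compound 3 (0.90 log units; beyond the scatter). Going by these compounds alone, the earlier step, no change at the digits printed from compound 1 to compound 2 (within the scatter), concerned only the tetrahydroisoquinolinyl group and showed no such movement, so compound 3 is the first sign that this series can be made longer-lived in this assay, and the change that does it lies in the ring and not in that group. No measurement in hand accounts for the longer life of compound 3.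

The compounds shown leave open whether both selenium atoms are needed, as a ring holding one sulfur and one selenium atom would show, and how a ring with a carbon-carbon chain in place of the two selenium atoms would behave. They also leave open whether the same exchange carries over to the 1,2,3,4-tetrahydroisoquinolin-1-yl group of compound 2.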